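This account rests on a few compounds, and the source may have more. Where it says the series, first, only, none or still open, it means among the compounds named here.

Of the compounds shown here, three share one core and have been measured in a functional assay on brain (Rattus norvegicus, strain Wistar) for inhibition; a lower number here means a stronger inhibitor, a higher number a weaker inhibitor. Compound 2 `COc1ccc(-c2c(C)[nH]c(=O)n2C)cc1` gives 147000 nM; compound 1 `CCCCOc1ccc(-c2c(C)[nH]c(=O)n2C2CCCCC2)cc1` gives 13900 nM; compound 3 `CCCCCCCCOc1ccc(-c2c(C)[nH]c(=O)n2C)cc1` gives 4000 nM. Compound 2 therefore stands highest of the three numbers, and its gap to compound 1 as well as its gap to compound 3 lies beyond the scatter.

Compound 4 `Cc1[nH]c(=O)n(C)c1-c1ccc(-c2ccccc2)cc1` is not yet measured. It differs from compound 2 in one place: phenyl in place of methoxy on an aromatic carbon. For the measured compounds named here, the one step that bears on this is the change at the same position from compound 2 to compound 3, a 37-fold lower number from compound 2 to compound 3 (1.57 log units; beyond the scatter), where a much larger group in place of the small methoxy brought a large fall. Phenyl is also larger than methoxy, though smaller than the heptyl-extended chain, so a fall for compound 4 in this assay is expected, but a smaller one than a 37-fold lower number from compound 2 to compound 3 (1.57 log units; beyond the scatter). Compound 4 is estimated at 25000 nM, with a likely range of 6000 nM to 100000 nM, an expected step of a 5.9-fold lower number from compound 2 to compound 4 (0.77 log units; beyond the scatter).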

Compound 4, half-maximal inhibitory concentration: 6300 nM
The estimate for compound 4 lay 4.0-fold (0.60 log units) above the measured number; measured number inside the range.
By their numbers in this assay, from the lowest: compounds 3 and 4 (each within the scatter of the next); then compound 1; then compound 2.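

In this assay, phenyl in place of methoxy gives a 23-fold lower number from compound 2 to compound 4 (1.37 log units; beyond the scatter), so a large fall at this position does not require the oxygen or a chain, which compound 3 keeps and compound 4 lacks. An all-carbon aromatic ring with no hydrogen-bond acceptor does as well as the long chain: compound 3 gives 4000 nM and compound 4 gives 6300 nM, two values within the scatter of each other. Nothing available explains why either change has this effect.

Going by these compounds, it remains open whether a saturated ring such as cyclohexyl, or a charged group such as an amine or a carboxylic acid, would be tolerated at this position. On these data alone, it is also open whether phenyl would have the same effect on the core of compound 1.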